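The source may report more compounds than this note shows. Statements on the series, on what has been measured and on what is new or still open speak of the compounds shown alone.

Working notes on the series built on compound 1 `Cc1noc(-c2cc3ccccc3[nH]2)n1`, all tested in a functional assay on MIA PaCa-2 cells (Homo sapiens) for antiproliferative activity, read by WST assay, with a stated time of 72 h; on this read-out lower numbers stand for stronger inhibition and higher numbers for weaker inhibition. In this assay compound 1 gives 30500 nM. Compound 2 `Cc1noc(-c2cc3cc(F)ccc3[nH]2)n1` gives 19400 nM in this assay, and the step of a 1.6-fold lower number from compound 1 to compound 2 (0.20 log units; within the scatter) stays within the scatter. Compound 3 `Cc1noc(-c2cc3cc(Cl)ccc3[nH]2)n1` reaches only a limit in this assay, > 50000 nM, as noted by the limit of > 50000 nM in this assay, at which 1 of the 3 values shown sits. The steps of an at least 1.6-fold higher number from compound 1 to compound 3 (0.21 log units; that floor lies within the scatter) and an at least 2.5-fold higher number from compound 2 to compound 3 (0.41 log units; beyond the scatter) concern a halogen on an aromatic carbon of the shared core, not the methyl. Compound 4 `c1ccc(-c2noc(-c3cc4ccccc4[nH]3)n2)cc1` carries phenyl in place of methyl on an aromatic carbon. Among the compounds with values here, no measured step touches that group, so the size and direction rest on no precedent; the expectation is a step within the scatter, a 1.5-fold lower number from compound 1 to compound 4 (0.18 log units; within the scatter). Compound 4 is thus estimated at 20000 nM, with a range from 4000 nM to 80000 nM.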

Compound 4, half-maximal inhibitory concentration: 22000 nM
Compound 4: the middle estimate sits 1.1-fold (0.04 log units) below what was measured; the range from low to high includes it.
By their numbers in this assay, from the lowest: compounds 2, 4 and 1 (each within the scatter of the next). At a limit, above all of these: compound 3.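

Phenyl in place of methyl gives a 1.4-fold lower number from compound 1 to compound 4 (0.14 log units; within the scatter) in this assay, the first reading at this position, as the earlier steps concerned a halogen elsewhere on the shared core. Here, a group of 6 heavy atoms with a six-membered aromatic ring is thus accommodated without a step beyond the scatter. Compound 3 remains a limit: the limit of > 50000 nM in this assay, at which 1 of the 4 values shown sits.

On these data alone, whether an amine, a carboxylic acid or a longer chain at this position would behave the same way stays open. Also open, as far as these compounds go, is whether any group here gives a step beyond the scatter.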